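Acyl group variation at the thioester of compound 2

This account rests on a few compounds, and the source may have more. Where it says the series, first, only, none or still open, it means among the compounds named here.

Compound 2 `CC(=O)SCCCCCCNC(=O)c1cc(-c2ccncc2)n[nH]1` holds the highest of the two numbers in a functional assay on HCT-116 cells (Homo sapiens) for inhibition, read by MTT assay, with a stated time of 96 h; on this read-out lower numbers stand for stronger inhibition of growth and higher numbers for weaker inhibition of growth: compound 2 gives 41100 nM. Compound 1 `O=C(OCc1ccccc1)SCCCCCCNC(=O)c1cc(-c2ccncc2)n[nH]1` gives 18200 nM, so compound 1 lies closer to strong inhibition than compound 2. Compound 3 `O=C(NCCCCCCS)c1cc(-c2ccc3ccccc3c2)n[nH]1` reaches only a limit of the assay, > 50000 nM. For the measured compounds named here, the single step with two numbers behind it ran a 2.3-fold higher number from compound 1 to compound 2 (0.35 log units; beyond the scatter). Compound 4 `CC(C)C(=O)SCCCCCCNC(=O)c1cc(-c2ccncc2)n[nH]1` differs from compound 2 by isopropyl in place of methyl on a carbonyl carbon. The step that bears on this carbonyl carbon is a 2.3-fold higher number from compound 1 to compound 2 (0.35 log units; beyond the scatter), a modest one; a smaller change of the same kind is expected to move the number by no more than that, and likely within the scatter. Compound 4 is therefore estimated at 32000 nM, between 15000 nM and 70000 nM, an expected step of a 1.3-fold lower number from compound 2 to compound 4 (0.11 log units; within the scatter).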

Compound 4, concentration for 50% growth inhibition: 22700 nM
Estimate against measurement, compound 4: 1.4-fold (0.15 log units) above; the measured number falls inside the stated range.
By their numbers in this assay, from the lowest: compounds 1, 4 and 2 (each within the scatter of the next, the first and the last beyond it). At a limit, above all of these: compound 3.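

In this assay, neither replacement on the carbonyl carbon gives a step beyond the scatter: isopropyl in place of methyl gives a 1.8-fold lower number from compound 2 to compound 4 (0.26 log units; within the scatter), and isopropyl in place of benzyloxy gives a 1.2-fold higher number from compound 1 to compound 4 (0.10 log units; within the scatter). Compound 4 therefore cannot be separated from compound 1 or compound 2, even though those two are separated from each other. No measured property at hand bears on this change. Still open, on these data alone, is whether an amine or a carboxylic acid on this carbonyl carbon would move the number beyond the scatter.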